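Cyclooctyl for cyclopropyl on the amide nitrogen

The compounds below may be only part of what the source reports. "The series", "measured", "known", "first", "only" and "open" are said of these compounds alone.

In an ADME assay on MDBK cells (Bos taurus) for cytotoxicity, read by MTT assay (a lower number here means that less compound is tolerated, a higher number that more compound is tolerated), compound 1 `CC(C)(C)CC(=O)N(CCCCCCN1C[C@H](O)[C@@H](O)[C@H](O)[C@H]1CO)C1CCCCC1` gives only a limit of the assay, > 500000 nM. Compound 2 `CC(C)(C)C(=O)N(CCCCCCN1C[C@H](O)[C@@H](O)[C@H](O)[C@H]1CO)c1ccc(F)cc1F` likewise gives only a limit, > 500000 nM. Compound 3 `CC(C)(C)C(=O)N(CCCCCCN1C[C@H](O)[C@@H](O)[C@H](O)[C@H]1CO)C1CC1` also gives only a limit, > 500000 nM. Between the last two lies a step that the two limits leave unreadable from compound 2 to compound 3, and the sole evidence on hand is the limit of > 500000 nM in this assay, at which 3 of the 3 values shown sit. Compound 4 `CC(C)(C)C(=O)N(CCCCCCN1C[C@H](O)[C@@H](O)[C@H](O)[C@H]1CO)C1CCCCCCC1` differs from compound 3 in one place: cyclooctyl in place of cyclopropyl on an amide-type nitrogen. No measured step shows how such a change moves this assay, so no direction can be drawn from the numbers shown. Compound 4 is therefore expected once more to reach the limit, with an estimated value of 500000 nM, ranging from 250000 nM to 1000000 nM. The expected step is a number no higher from compound 3 to compound 4 (the limit leaves the size open), nothing beyond the scatter.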

Compound 4, half-maximal cytotoxic concentration: 270000 nM
For compound 4 the middle estimate is 1.9-fold (0.27 log units) above the measured one; the measured number falls inside the stated range.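

In this assay compound 4, with cyclooctyl on the amide-type nitrogen, is the first compound shown to give a number rather than a limit. Replacing cyclopropyl gives an at least 1.8-fold lower number from compound 3 to compound 4 (0.26 log units; that floor lies within the scatter), and replacing 2,4-difluorophenyl gives an at least 1.8-fold lower number from compound 2 to compound 4 (0.26 log units; that floor lies within the scatter). Each step starts from a limit, so only its floor can be read: the limit of > 500000 nM in this assay, at which 3 of the 4 values shown sit.

Going by these compounds, the true size of both steps remains open. Also open, on these data alone, is how a cyclopentyl ring or a longer open chain on this nitrogen would behave, and whether the number tracks ring size at all.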